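Swapping a Bromophenyl for a Chlorophenyl: Cytotoxicity Outlook

The compounds below may be only part of what the source reports. "The series", "measured", "known", "first", "only" and "open" are said of these compounds alone.

Compound 1 `NC(=S)Nc1cccc(OCCCCCCCCNC(=S)Nc2ccccc2)c1` in an ADME assay on Huh-7 cells (Homo sapiens) for cytotoxicity (on this read-out higher numbers stand for lower toxicity in this test and lower numbers for higher toxicity in this test), gives > 50000 nM, which is a limit of the assay rather than a number.
Compound 2 `NC(=S)Nc1cccc(OCCCCCCCCNC(=S)Nc2ccc(Br)cc2)c1` gives 18000 nM.
Compound 3 `NC(=S)Nc1cccc(OCCCCCCCCNC(=S)Nc2ccccc2Br)c1` gives 36000 nM.

Among the two real numbers, compound 3 has the higher one, though the step of a 2.0-fold higher number from compound 2 to compound 3 (0.30 log units; within the scatter) is within the scatter. Compound 4 `NC(=S)Nc1cccc(OCCCCCCCCNC(=S)Nc2ccc(Cl)cc2)c1` differs from compound 3 by 4-chlorophenyl in place of 2-bromophenyl on an amide-type nitrogen. Among the compounds with values here, the steps that bear on this are the two bromo additions, an at least 2.7-fold lower number from compound 1 to compound 2 (0.44 log units; beyond the scatter) and an at least 1.3-fold lower number from compound 1 to compound 3 (0.14 log units; that floor lies within the scatter), and the switch between bromophenyl isomers, a 2.0-fold higher number from compound 2 to compound 3 (0.30 log units; within the scatter). From the compounds shown here alone, a 4-chlorophenyl resembles the 4-bromophenyl of compound 2, so a modestly lower number is expected, while chloro in place of bromo is untested here. Compound 4 is expected near 22000 nM, between 9000 nM and 50000 nM. The estimated step is a 1.6-fold lower number from compound 3 to compound 4 (0.21 log units; within the scatter).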

Compound 4, half-maximal cytotoxic concentration: 18000 nM
For compound 4 the middle estimate is 1.2-fold (0.09 log units) above the measured one; the range from low to high includes it.
By their numbers in this assay, from the lowest: compounds 2, 4 and 3 (each within the scatter of the next). At a limit, above all of these: compound 1.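

In this assay, within the data shown here, the first look at chloro in place of bromo gives no change at the digits printed from compound 2 to compound 4 (within the scatter), so on this evidence the two halogens cannot be told apart on this ring. The comparison with the other bromo isomer shows a 2.0-fold lower number from compound 3 to compound 4 (0.30 log units; within the scatter), which also does not separate 4-chlorophenyl from 2-bromophenyl. Chloro in place of hydrogen gives an at least 2.7-fold lower number from compound 1 to compound 4 (0.44 log units; beyond the scatter), matching the bromo addition in compound 2, though this step rests on a limit of the assay: the limit of > 50000 nM in this assay, at which 1 of the 4 values shown sits.

Still open, from the compounds shown here alone, is how a 2-chlorophenyl would read in this assay. So is the effect of an amine or a carboxylic acid on the phenyl ring.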